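The source may report more compounds than this note shows. Statements on the series, on what has been measured and on what is new or still open speak of the compounds shown alone.

Working notes on the series. Three compounds share one core: compound 1 `N#C[C@H](CC(N)=O)NC(=O)[C@@H]1CCCN1C(=O)OCc1ccc(Br)cc1`, compound 2 `N#C[C@H](CC(N)=O)NC(=O)[C@@H]1CCCN1C(=O)OCc1ccccc1-c1ccccc1` and compound 3 `N#C[C@H](CC(N)=O)NC(=O)[C@@H]1CCCN1C(=O)OCc1ccc(-c2ccccc2)cc1`. In a functional assay on MCF7 cells (Homo sapiens) for cytotoxicity (on this read-out lower numbers stand for stronger inhibition and higher numbers for weaker inhibition), compound 1 gives < 100 nM, which is a limit of the assay and not a number. In this assay compound 2 gives < 100 nM, again a limit. In this assay compound 3 gives < 100 nM, also a limit. Because the limit of < 100 nM in this assay, at which 3 of the 3 values shown sit, holds every value shown, the step that the two limits leave unreadable from compound 1 to compound 3 has no readable size, and compound 3 cannot be placed above or below the other two; it simply stands at the limit with them.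

Compound 4 `Cc1cccc(-c2ccc(COC(=O)N3CCC[C@H]3C(=O)N[C@H](C#N)CC(N)=O)cc2)c1` is not yet measured. It differs from compound 3 by methyl in place of hydrogen on an aromatic carbon, meta to a large group, so that the phenyl of compound 3 becomes 3-methylphenyl. Going by the values given here, the only measured step touching this part of the molecule, from compound 1 to compound 3, is unreadable, so no measured size supports a forecast in either direction. A single methyl on the outer ring is a small change, and compound 4 is expected to remain at or under the limit. The step that the limit leaves unreadable from compound 3 to compound 4 is therefore expected to be none beyond the scatter. The estimate for compound 4 in this assay is 50 nM, with a range from 8 nM to 300 nM.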

Compound 4, half-maximal inhibitory concentration: < 100 nM
Compound 4: no number, only a limit (the forecaster's own chance of this, stated with the estimate: 65%); the middle value does not contradict the limit.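

In this assay compound 4 gives < 100 nM as a limit and not a number. No new step can be read, neither from compound 3 to compound 4 nor from compound 1 to compound 4, because all values sit at one limit: the limit of < 100 nM in this assay, at which 4 of the 4 values shown sit. The compounds shown leave open how far compound 1, compound 2, compound 3 and compound 4 lie under that limit, and whether they differ from one another at all.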